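The source may report more compounds than this note shows. Statements on the series, on what has been measured and on what is new or still open speak of the compounds shown alone.

Compound 1 `CCc1cc(-c2noc(-c3cc(C)cc(CN(C)C)c3)n2)cc(C)c1OC[C@@H](O)CNC(=O)CO`, compound 2 `CCc1cc(-c2noc(-c3cc(C)cc(CN(C)CC(C)C)c3)n2)cc(C)c1OC[C@@H](O)CNC(=O)CO`, compound 3 `CCc1cc(-c2noc(-c3cc(C)c(CN(C)C)s3)n2)cc(C)c1OC[C@@H](O)CNC(=O)CO` and compound 4 `CCc1cc(-c2noc(-c3cc(C)c(CN(C)CC(C)C)s3)n2)cc(C)c1OC[C@@H](O)CNC(=O)CO` share a core and differ in the attached groups. In an ADME assay on liver (strain Wistar) for metabolic stability, with Liver microsome (Rattus norvegicus) as the target, read by LC-MS, using microsomes and NADPH, with a stated time of 15 min, tested at 1 uM (on this read-out lower numbers stand for slow clearance and higher numbers for fast clearance), compound 1 gives only a limit, > 4800 mL.min-1.g-1. Compound 2 gives 740 mL.min-1.g-1, and compound 3 gives 8100 mL.min-1.g-1, the highest number among the measured compounds. The change from compound 1 to compound 2, (isopropyl in place of hydrogen on a saturated chain carbon bound to an amine nitrogen), brings an at least 6.4-fold lower number from compound 1 to compound 2 (0.81 log units; beyond the scatter); the limit of > 4800 mL.min-1.g-1 in this assay, at which 1 of the 3 values shown sits, leaves the full size of that step unread. Compound 3 carries a different core, (5-((dimethylamino)methyl)-4-methylthiophen-2-yl in place of 3-((dimethylamino)methyl)-5-methylphenyl on an aromatic carbon), and a step that the limit leaves unreadable from compound 1 to compound 3. Compound 4 carries the same kind of change as compound 2, (isopropyl in place of hydrogen on a saturated chain carbon bound to an amine nitrogen), at a place described in identical words. Because an at least 6.4-fold lower number from compound 1 to compound 2 (0.81 log units; beyond the scatter) was seen, a step of a 6.2-fold lower number from compound 3 to compound 4 (0.79 log units; beyond the scatter) is expected. Compound 4 is therefore estimated at 1300 mL.min-1.g-1, between 500 mL.min-1.g-1 and 3500 mL.min-1.g-1.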

Compound 4, intrinsic clearance in microsomes: 14000 mL.min-1.g-1
Estimate against measurement, compound 4: 11-fold (1.03 log units) below; the whole stated range lies below it.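

In this assay, adding the isopropyl on a saturated chain carbon bound to an amine nitrogen of compound 3 brings a 1.7-fold higher number from compound 3 to compound 4 (0.24 log units; within the scatter), a step that cannot be told apart from repeat scatter. The change therefore does not carry from one core to the other, since the steps on the two cores differ: the same change on two cores in this assay, an at least 6.4-fold lower number (0.81 log units; beyond the scatter) from compound 1 to compound 2 and a 1.7-fold higher number (0.24 log units; within the scatter) from compound 3 to compound 4, at least 11-fold (1.04 log units) apart, beyond the scatter of two such steps. These two pairs do not explain that difference, and they set no rule for any other core.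

The compounds shown leave open how a longer chain, such as n-hexyl, in place of the isobutyl would behave on each core. They also leave open whether a morpholine in place of the isobutyl(methyl)amino group would follow either core's pattern.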